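A few compounds are considered here, and "the series" means these few. Any claim that something is new, unique, unknown or untested is made for them only; others in the source may bear on it.

Compound 1 `CCOC(=O)[C@@H]1CCCN(S(=O)(=O)c2ccc(S(=O)(=O)N3CCOCC3)cc2)C1`: 23400 nM.
Compound 2 `CCOC(=O)[C@@H]1CCCN(S(=O)(=O)c2ccc(S(=N)(=O)N(CC)CC)cc2)C1`: 3600 nM.
Compound 3 `CCOC(=O)[C@@H]1CCCN(S(=O)(=O)c2ccc(S(=O)(=O)N(CC)C(C)C)cc2)C1`: 1600 nM.

In a functional assay on BXPC-3 cells (Homo sapiens) for inhibition, read by MTT assay, with a stated time of 7 days (on this read-out higher numbers stand for weaker inhibition and lower numbers for stronger inhibition), compound 3 has the lowest of the three numbers; the nearest step to it is a 2.3-fold lower number from compound 2 to compound 3 (0.35 log units; beyond the scatter) and the furthest is a 15-fold lower number from compound 1 to compound 3 (1.17 log units; beyond the scatter). Compound 4 `CCOC(=O)[C@@H]1CCCN(S(=O)(=O)c2ccc(C(=O)N(CC)CC)cc2)C1` differs by diethylcarbamoyl in place of ethyl(isopropyl)sulfamoyl on an aromatic carbon, on an aromatic carbon of a six-membered aromatic ring of carbon only, para to a large group. Among the measured compounds shown here, no measured step exchanges a sulfamoyl for a carbamoyl. For the measured compounds named here, the only guidance is that altering the group at this position moved the number by a 6.5-fold lower number from compound 1 to compound 2 (0.81 log units; beyond the scatter) and by a 15-fold lower number from compound 1 to compound 3 (1.17 log units; beyond the scatter), so this part of the molecule is sensitive to change. Removing the sulfonyl entirely is therefore expected to weaken inhibition somewhat. Compound 4 is estimated at 5000 nM, within 1500 nM to 20000 nM. That expected step is a 3.1-fold higher number from compound 3 to compound 4 (0.49 log units; beyond the scatter).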

Compound 4, half-maximal inhibitory concentration: 640 nM
Estimate against measurement, compound 4: 7.8-fold (0.89 log units) above; the measured number lies below the stated range.
By their numbers in this assay, from the lowest: compound 4; then compound 3; then compound 2; then compound 1.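

In this assay, a sulfonyl at this aromatic carbon proves dispensable: diethylcarbamoyl brings a 2.5-fold lower number from compound 3 to compound 4 (0.40 log units; beyond the scatter), and it also compares well with the other two groups, with a 5.6-fold lower number from compound 2 to compound 4 (0.75 log units; beyond the scatter) and a 37-fold lower number from compound 1 to compound 4 (1.56 log units; beyond the scatter). The step from compound 3 also changes the amine, so the carbonyl's share of the gain stays unseparated. No measurement at hand explains the gain. Open, from the compounds shown here alone, is whether morpholin-4-ylcarbonyl would keep this level, and whether a longer chain such as dipropylcarbamoyl or a carboxylic acid at this carbon would go further.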